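Removing the hydroxy group from compound 3

This account rests on a few compounds, and the source may have more. Where it says the series, first, only, none or still open, it means among the compounds named here.

Three compounds have so far been measured in an assay on microsomes from intestine for inhibition of acyl-CoA:cholesterol acyltransferase (Oryctolagus cuniculus); a lower number here means a stronger inhibitor, a higher number a weaker inhibitor:

Compound 1 `CC(C)c1cccc(C(C)C)c1NC(=O)NC1CCc2ccccc21` gives 910 nM
Compound 2 `CC(C)c1cccc(C(C)C)c1NC(=O)NCC1(O)CCCc2ccccc21` gives 350 nM
Compound 3 `CC(C)c1cccc(C(C)C)c1NC(=O)NCC1(O)CCc2ccccc21` gives 810 nM

Compound 3 stands second highest of these three numbers. Compound 1 sits within the scatter of it, while compound 2 gives a number beyond the scatter on the lower side. Compound 4 `CC(C)c1cccc(C(C)C)c1NC(=O)NCC1CCc2ccccc21` differs from compound 3 in one place only: hydrogen in place of hydroxy on a saturated ring carbon. Going by the values given here, no pair of measured compounds shows this change by itself, so no measured step guides the expectation. Compound 1, which also carries no hydroxy group, and compound 3 give numbers within the scatter of each other. The expected change is a 1.1-fold higher number from compound 3 to compound 4 (0.05 log units; within the scatter), no larger than the scatter. Compound 4 is therefore estimated at 900 nM, with a range from 350 nM to 2500 nM.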

Compound 4, half-maximal inhibitory concentration: 27 nM
For compound 4 the middle estimate is 33-fold (1.52 log units) above the measured one, and the stated range ends above it.
By their numbers in this assay, from the lowest: compound 4; then compound 2; then compounds 3 and 1 (each within the scatter of the next).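

Replacing hydroxy with hydrogen on this saturated ring carbon gives a 30-fold lower number from compound 3 to compound 4 (1.48 log units; beyond the scatter) in this assay and is the first change shown on its own in a measured pair. It shows that this position is highly sensitive to what it carries, and that here hydrogen gives a far stronger inhibitor than hydroxy. No measurement offered here explains why the step is so large.

The compounds shown leave open whether a methyl group, a fluorine atom or an amine on this carbon would behave more like hydrogen or like hydroxy. They also leave open whether the same change in compound 2 would give a step of similar size.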